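This account rests on a few compounds, and the source may have more. Where it says the series, first, only, none or still open, it means among the compounds named here.

Series on the shared core of compound 1 `O=S(=O)(Nc1ccc(-c2nc3ccccc3o2)cc1)c1ccc(Cl)s1` with varied groups on the sulfonyl sulfur. In an assay on cells for inhibition of HSP60/HSP10 (Homo sapiens), with a stated time of 60 min (on this read-out higher numbers stand for weaker inhibition and lower numbers for stronger inhibition), compound 1 gives 31000 nM. Compound 2 `C=Cc1ccc(S(=O)(=O)Nc2ccc(-c3nc4ccccc4o3)cc2)cc1` is recorded only as a limit in this assay: compound 2 gives > 100000 nM. Among the compounds with values here, the single measured step, an at least 3.2-fold higher number from compound 1 to compound 2 (0.50 log units; beyond the scatter), rests on (the limit of > 100000 nM in this assay, at which 1 of the 3 values shown sits). Compound 3 `O=S(=O)(Nc1ccc(-c2nc3ccccc3o2)cc1)c1cccc(C(F)(F)F)c1` gives 57000 nM in this assay, the highest of the two numbers, with compound 1 as nearest neighbour within the scatter. Compound 4 `O=S(=O)(Nc1ccc(-c2nc3ccccc3o2)cc1)c1cccc(O)c1` differs from compound 3 by hydroxy in place of trifluoromethyl on an aromatic carbon. Within the data shown here, no measured step involves a hydroxy or a trifluoromethyl, and the one known step concerns a different change, so no step beyond the scatter is expected in this assay. Compound 4 is therefore estimated at 50000 nM, ranging from 15000 nM to 150000 nM, the expected step being a 1.1-fold lower number from compound 3 to compound 4 (0.06 log units; within the scatter).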

Compound 4, half-maximal inhibitory concentration: 62000 nM
Compound 4: middle estimate off by 1.2-fold (0.09 log units), on the low side, and the stated range covers the measured number.
By their numbers in this assay, from the lowest: compounds 1, 3 and 4 (each within the scatter of the next). At a limit, above all of these: compound 2.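

In this assay, on this aromatic carbon meta to a large group, hydroxy in place of trifluoromethyl gives a 1.1-fold higher number from compound 3 to compound 4 (0.04 log units; within the scatter), so the two groups cannot be told apart here even though only hydroxy brings a hydrogen-bond donor. The step of a 2.0-fold higher number from compound 1 to compound 4 (0.30 log units; within the scatter) likewise does not separate 3-hydroxyphenyl from 5-chlorothiophen-2-yl on the sulfonyl sulfur. The step of an at least 1.6-fold lower number from compound 2 to compound 4 (0.20 log units; that floor lies within the scatter) rests on a limit and does not separate 3-hydroxyphenyl from 4-vinylphenyl: the limit of > 100000 nM in this assay, at which 1 of the 4 values shown sits.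

On these data alone, whether an amine or a carboxylic acid on this aromatic carbon would give a step beyond the scatter stays open. Changes to the shared core away from the sulfonyl sulfur also stay open.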